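4-(1H-imidazol-1-yl)butyl to 3-hydroxypropyl: compound 3 to compound 4

The compounds below may be only part of what the source reports. "The series", "measured", "known", "first", "only" and "open" are said of these compounds alone.

In a functional assay on K562 cells (Homo sapiens) for antiproliferative activity, read by MTT assay, with a stated time of 48 h (on this read-out lower numbers stand for stronger inhibition and higher numbers for weaker inhibition), compound 3 (`Cn1cc(C2=C(c3nn(CCCCn4ccnc4)c4ncccc34)C(=O)NC2=O)c2ccccc21`) gives 31800 nM and lies within the scatter of compound 2 (`CN(C)CCCn1nc(C2=C(c3cn(C)c4ccccc34)C(=O)NC2=O)c2cccnc21`) at 50400 nM in the same read-out. Compound 1 (`Cn1cc(C2=C(c3nn(CCCn4cncn4)c4ncccc34)C(=O)NC2=O)c2ccccc21`) reads > 100000 nM in this assay and this is a limit of the assay, not a number.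

Compound 4 (`Cn1cc(C2=C(c3nn(CCCO)c4ncccc34)C(=O)NC2=O)c2ccccc21`) carries hydroxy in place of (1H-imidazol-1-yl)methyl on a saturated chain carbon, three bonds along the chain from an aromatic nitrogen.

Measured changes at this place have given an at least 3.1-fold lower number from compound 1 to compound 3 (0.49 log units; beyond the scatter) and an at least 1.9-fold lower number from compound 1 to compound 2 (0.29 log units; that floor lies within the scatter) and a 1.6-fold lower number from compound 2 to compound 3 (0.20 log units; within the scatter) so far. None of these involves hydroxy, so they offer only a rough guide to size. The starting point is compound 3 at 31800 nM and no step beyond the scatter is expected in this assay for this change. The expected move is a 1.4-fold higher number from compound 3 to compound 4 (0.15 log units; within the scatter) and it is estimated to lean toward a higher number. For compound 4 the estimate is 45000 nM with an expected range of 15000 nM to 100000 nM in this read-out.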

Compound 4, half-maximal inhibitory concentration: 85800 nM
Compound 4: the middle estimate sits 1.9-fold (0.28 log units) below what was measured; low and high end bracket the measured number.
By their numbers in this assay, from the lowest: compounds 3, 2 and 4 (each within the scatter of the next, the first and the last beyond it). At a limit, above all of these: compound 1.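

In this assay, among these compounds, hydroxy in place of (1H-imidazol-1-yl)methyl gives a 2.7-fold higher number from compound 3 to compound 4 (0.43 log units; beyond the scatter), the first step at this place that lies beyond the scatter with a measured number at both ends. Hydroxy in place of dimethylamino gives a 1.7-fold higher number from compound 2 to compound 4 (0.23 log units; within the scatter), so these data do not separate hydroxy from dimethylamino. Compound 1 reads > 100000 nM, which is a limit of the assay and not a number. Hydroxy in place of 1H-1,2,4-triazol-1-yl gives an at least 1.1-fold lower number from compound 1 to compound 4 (0.06 log units; that floor lies within the scatter), and this step is only a floor because of that limit: the limit of > 100000 nM in this assay, at which 1 of the 4 values shown sits.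

The step from compound 3 to compound 4 removes the imidazole ring and also ends the chain as 3-hydroxypropyl rather than 4-(1H-imidazol-1-yl)butyl, and these two parts of the change remain unseparated. Open too, as far as these compounds go, is how a 4-hydroxybutyl chain, a morpholine or a carboxylic acid at this place would read.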